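The source may hold more compounds than are shown below. What is called first, only, known or untested is meant among the compounds shown, and "the series" means these compounds.

In an ADME assay on Vero cells (Chlorocebus sabaeus) for cytotoxicity, read by MTT assay, with a stated time of 96 h (on this read-out lower numbers stand for higher toxicity in this test and higher numbers for lower toxicity in this test), compound 1 `COc1ccc(-c2nc3cc(C(C)=O)ccc3n2C2CCCCC2)cc1` gives 30000 nM. Compound 2 `C/C(=N\NC(N)=O)c1ccc2c(c1)nc(-c1ccccc1)n2C1CCCCC1` reaches only a limit of the assay, > 100000 nM. Compound 3 `C/C(=N\NC(N)=S)c1ccc2c(c1)nc(-c1ccccc1)n2C1CCCCC1` gives 20000 nM, a number within the usual scatter of the one for compound 1, so these two stand together on the numbers shown.

Compound 4 `COc1ccc(-c2nc3cc(/C(C)=N/NC(N)=S)ccc3n2C2CCCCC2)cc1` differs from compound 3 in one place: methoxy in place of hydrogen on an aromatic carbon. The phenyl thus becomes 4-methoxyphenyl, while the rest of compound 3 stays as it is. Among the compounds with values here, only one measured step is available, an at least 5.0-fold lower number from compound 2 to compound 3 (0.69 log units; beyond the scatter). That change sits on an amine nitrogen, away from the place altered here, so it says nothing about the size of the new step. Within the data shown here, compound 1 already carries 4-methoxyphenyl and gives 30000 nM, but no measured pair isolates that group. Its number therefore offers only weak support, though it gives no sign of a large shift in this assay.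

Among the measured compounds shown here, with no measured step bearing directly on this change, no move in either direction beyond the scatter is expected, and the expected step is no change at the digits printed from compound 3 to compound 4 (within the scatter). For compound 4 the estimate is 20000 nM, with an expected range from 7000 nM to 60000 nM.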

Compound 4, half-maximal cytotoxic concentration: 40000 nM
For compound 4 the middle estimate is 2.0-fold (0.30 log units) below the measured one; the range from low to high includes it.
By their numbers in this assay, from the lowest: compounds 3, 1 and 4 (each within the scatter of the next). At a limit, above all of these: compound 2.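

In this assay, methoxy in place of hydrogen on an aromatic carbon, para to a large group, gives a 2.0-fold higher number from compound 3 to compound 4 (0.30 log units; within the scatter) and so does not separate 4-methoxyphenyl from phenyl at this place on the numbers shown. Within the data shown here, this is the first measured step at this position, and it shows that the group can be added here without a shift beyond the scatter. With 4-methoxyphenyl in place, the change of group on an aromatic carbon gives a 1.3-fold higher number from compound 1 to compound 4 (0.12 log units; within the scatter) and likewise leaves the two compounds together, and nothing shown gives a cause for either result.

As far as these compounds go, whether a chlorine atom, a hydroxyl or an amine at the same place would move the number beyond the scatter stays open. From the compounds shown here alone, it also stays open whether an at least 5.0-fold lower number from compound 2 to compound 3 (0.69 log units; beyond the scatter) would recur with 4-methoxyphenyl in place of phenyl.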